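Terminal aryl substituent exchange: trifluoromethoxy to hydroxymethyl

The source may report more compounds than this note shows. Statements on the series, on what has been measured and on what is new or still open speak of the compounds shown alone.

Compound 1, `CC[C@H](C)[C@H](N)CN(C(=O)[C@@H]1C[C@H]1c1ccccc1)c1ccc(-c2ccc(C(F)(F)F)cc2)cc1`: in a functional assay for agonist activity at G protein-coupled receptor 88 (Homo sapiens), read by HTRF and cAMP accumulation (on this read-out lower numbers stand for an effect already at smaller amounts and higher numbers for an effect only at larger amounts of compound), compound 1 gives 340 nM.
Compound 2, `CC[C@H](C)[C@H](N)CN(C(=O)[C@@H]1C[C@H]1c1ccccc1)c1ccc(-c2ccc(OC(F)(F)F)cc2)cc1`: in this assay compound 2 gives 170 nM.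

Compound 2 holds the lower of the two numbers, but the step of a 2.0-fold lower number from compound 1 to compound 2 (0.30 log units; within the scatter) lies within the scatter, so no order between the two compounds is claimed.

Compound 3, `CC[C@H](C)[C@H](N)CN(C(=O)[C@@H]1C[C@H]1c1ccccc1)c1ccc(-c2ccc(CO)cc2)cc1`, differs from compound 2 by hydroxymethyl in place of trifluoromethoxy on an aromatic carbon. For the measured compounds named here, the only measured step at this position is a 2.0-fold lower number from compound 1 to compound 2 (0.30 log units; within the scatter), which was within the scatter and concerned a different entering group, so it gives no direct guide. The present exchange is larger, and a shift to a higher number in this assay, beyond the scatter, is expected: a 4.1-fold higher number from compound 2 to compound 3 (0.61 log units; beyond the scatter). Compound 3 is therefore estimated at 700 nM, with a range from 250 nM to 2500 nM.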

Compound 3, half-maximal effective concentration: 1100 nM
Beside the measured number, compound 3's estimate is 1.6-fold (0.20 log units) below it, within the range that was stated.
By their numbers in this assay, from the lowest: compounds 2 and 1 (each within the scatter of the next); then compound 3.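

In this assay, the terminal aryl substituent proves able to shift the number beyond the scatter: hydroxymethyl gives a 6.5-fold higher number from compound 2 to compound 3 (0.81 log units; beyond the scatter) and a 3.2-fold higher number from compound 1 to compound 3 (0.51 log units; beyond the scatter), whereas the exchange between trifluoromethyl and trifluoromethoxy stayed within it. Both steps point the same way, so the shift does not depend on which of those two groups serves as the reference. No other kind of measurement accompanies these numbers, and the shift stays unexplained.

Hydroxymethyl brings a hydrogen-bond donor and fewer heavy atoms in one exchange, and the compounds shown do not separate the two. From the compounds shown here alone, whether methoxy, aminomethyl or a carboxylic acid at this place would match hydroxymethyl or trifluoromethoxy remains open.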